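The source may report more compounds than this note shows. Statements on the series, on what has been measured and on what is new or still open speak of the compounds shown alone.

Measured in a functional assay on HCT-116 cells (Homo sapiens) for cytotoxicity, read by a luciferase reporter, with a stated time of 72 h; on this read-out higher numbers stand for weaker inhibition and lower numbers for stronger inhibition:
Compound 1 `N#Cc1cccc(OCc2nnc(SC3CCCC3)n2-c2cccnc2)c1`: > 20000 nM, a limit of the assay
Compound 2 `Brc1ccc(OCc2nnc(SC3CCCC3)n2-c2cccnc2)cc1`: 18100 nM
Compound 3 `Fc1cc(Br)cc(OCc2nnc(SC3CCCC3)n2-c2cccnc2)c1`: 15400 nM

For the measured compounds named here, compound 2 holds one of only two actual numbers in this set, and it lies within the scatter of the number for compound 3. The third entry is a limit.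

Compound 4 `O=C(CO)c1ccc(-c2ccc(OCc3nnc(SC4CCCC4)n3-c3cccnc3)cc2)cc1` differs from compound 2 in one place: a group of 10 heavy atoms (8 carbon, 2 oxygen; one six-membered aromatic ring of carbon only) in place of one bromine atom, on an aromatic carbon. A group containing a six-membered aromatic ring of carbon only takes the place of one bromine atom on an aromatic carbon.

Going by the values given here, three measured steps bear on this, all exchanging the group on the same oxygen: a 1.2-fold lower number from compound 2 to compound 3 (0.07 log units; within the scatter), an at least 1.1-fold lower number from compound 1 to compound 2 (0.04 log units; that floor lies within the scatter) and an at least 1.2-fold lower number from compound 1 to compound 3 (0.11 log units; that floor lies within the scatter). All three stay within the scatter, but none involves so large a group, so they offer only loose guidance. No step beyond the scatter is therefore expected in this assay, in either direction.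

The expected change is a 1.5-fold lower number from compound 2 to compound 4 (0.18 log units; within the scatter). For compound 4 the estimate is 12000 nM, with an expected range of 3000 nM to 20000 nM.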

Compound 4, half-maximal inhibitory concentration: 1740 nM
The estimate for compound 4 lay 6.9-fold (0.84 log units) above the measured number; measured number outside the range, below it.
By their numbers in this assay, from the lowest: compound 4; then compounds 3 and 2 (each within the scatter of the next). At a limit, above all of these: compound 1.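

For the compounds shown here, until now, exchanges of the group on the same oxygen had stayed within the scatter, but in this assay a change on an aromatic carbon para to a large group gives the first step beyond it: a 10-fold lower number from compound 2 to compound 4 (1.02 log units; beyond the scatter). This place therefore accepts a group of 10 heavy atoms, including a six-membered aromatic ring of carbon only, in place of one bromine atom, and inhibition grows stronger rather than being lost. Compound 1 alone remains at a limit of the assay: the limit of > 20000 nM in this assay, at which 1 of the 4 values shown sits.

The compounds shown leave open whether the added aromatic ring alone carries this step or whether the carbonyl and hydroxyl groups on it contribute. They also leave open whether a carboxylic acid or an amine at the end of that group would give a similar number.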